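The source may hold more compounds than are shown below. What is called first, only, known or untested is meant among the compounds shown, and "the series" means these compounds.

Of the compounds shown here, three sharing one core have been tested in a functional assay on cells for antagonist activity at Free fatty acid receptor 1 (Homo sapiens), read by TR-FRET and inositol phosphate accumulation, with a stated time of 2 h; a lower number here means a stronger inhibitor, a higher number a weaker inhibitor. Compound 1 `Cc1cc(COc2ccc(Cl)cc2)nc(-c2ccccn2)n1` gives 251 nM, compound 2 `Cc1cc(COc2ccccc2C#N)nc(-c2ccccn2)n1` gives 10000 nM, and compound 3 `CC1(C)CN(c2cc(COc3ccc(F)c(F)c3F)nc(-c3ccccn3)n2)C1` gives 25.1 nM, the lowest of the three numbers. The gaps from compound 3 up to compound 1 and up to compound 2 both lie beyond the usual scatter of repeated measurements, so compound 3 stands as the strongest inhibitor of this small set.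

Compound 4 `Fc1ccc(OCc2cc(OCC3COC3)nc(-c3ccccn3)n2)c(F)c1F` is built from compound 3 by a single change: (oxetan-3-yl)methoxy in place of 3,3-dimethylazetidin-1-yl on an aromatic carbon. For the measured compounds named here, no pair of measured compounds shows this particular exchange, so its effect cannot be read from the data and has to be estimated. Such a swap of one small ring-bearing group for another is expected to shift the number only moderately, more likely upward than downward, with a step in either direction remaining plausible. The step from compound 3 to compound 4 is therefore expected to be a 2.5-fold higher number from compound 3 to compound 4 (0.40 log units; beyond the scatter). Compound 4 is estimated at 63 nM, with a likely range from 20 nM to 250 nM.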

Compound 4, half-maximal inhibitory concentration: 316 nM
For compound 4 the middle estimate is 5.0-fold (0.70 log units) below the measured one; measured number above the stated range.
By their numbers in this assay, from the lowest: compound 3; then compounds 1 and 4 (each within the scatter of the next); then compound 2.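

In this assay, swapping only the group on this aromatic carbon gives a 13-fold higher number from compound 3 to compound 4 (1.10 log units; beyond the scatter), so this position clearly affects inhibition, which compounds 1, 2 and 3 could not show because they differ in more than one place. The size of the step also shows that matching the outgoing group's heavy-atom count and four-membered ring does not preserve activity, since the 3,3-dimethylazetidin-1-yl and (oxetan-3-yl)methoxy groups share both yet differ in their atoms and hydrogen-bond acceptor counts. No measurement here explains why the number rises.

Still open, going by these compounds, is which feature of the 3,3-dimethylazetidin-1-yl group matters: the ring, its nitrogen attachment or its two methyl groups. A plain azetidin-1-yl or an open-chain dimethylamino group at this position would help separate these features.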